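This account rests on a few compounds, and the source may have more. Where it says the series, first, only, none or still open, it means among the compounds named here.

Working notes on the series. Compound 1 `Fc1ccc(C2(c3ccc(F)cc3)CNC(c3cccc(F)c3)=N2)cc1` gives 10 nM in an assay on LM cells for displacement of a labelled ligand from Neuropeptide Y receptor type 5 (Homo sapiens); on this read-out higher numbers stand for weaker inhibition and lower numbers for stronger inhibition. Compound 2 `O=[N+]([O-])c1cccc(C2=NC(c3ccc(F)cc3)(c3ccc(F)cc3)CN2)c1` gives 4.3 nM in this assay, and the change of nitro in place of fluoro on an aromatic carbon shows a 2.3-fold lower number from compound 1 to compound 2 (0.37 log units; beyond the scatter). Compound 3 `Cc1cccc(C2=NC(c3ccc(F)cc3)(c3ccc(F)cc3)CN2)c1` gives 30 nM in this assay, the highest of the three numbers, with a 3.0-fold higher number from compound 1 to compound 3 (0.48 log units; beyond the scatter) as its nearest gap and a 7.0-fold higher number from compound 2 to compound 3 (0.84 log units; beyond the scatter) as its furthest. Compound 4 `Fc1ccc(C2(c3ccc(F)cc3)CNC(c3cccs3)=N2)cc1` differs from compound 3 by thiophen-2-yl in place of 3-methylphenyl on a carbon with a double bond to nitrogen. Among the measured compounds shown here, none of the measured steps bears directly on this change: all three exchange only the substituent on the six-membered ring, and none exchanges the ring itself. The three measured values together span a modest range, and the exchange of the whole aryl group gives no measured anchor. Compound 4 is therefore expected near the middle of that range, at 15 nM, with a plausible range from 4 nM to 60 nM. The estimated step of a 2.0-fold lower number from compound 3 to compound 4 (0.30 log units; within the scatter) means a modest lowering, resting on the fact that compound 1, with a plain 3-fluorophenyl, gives 10 nM.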

Compound 4, half-maximal inhibitory concentration: 54 nM
The estimate for compound 4 lay 3.6-fold (0.56 log units) below the measured number, and the stated range covers the measured number.
By their numbers in this assay, from the lowest: compound 2; then compound 1; then compounds 3 and 4 (each within the scatter of the next).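

Among the compounds shown here, the first exchange of the whole aryl group on the carbon with a double bond to nitrogen does not separate thiophen-2-yl from 3-methylphenyl in this assay (a 1.8-fold higher number from compound 3 to compound 4 (0.26 log units; within the scatter)). The same exchange does separate it from the two other six-membered rings, with thiophen-2-yl in place of 3-fluorophenyl (a 5.4-fold higher number from compound 1 to compound 4 (0.73 log units; beyond the scatter)) and, by more, in place of 3-nitrophenyl (a 13-fold higher number from compound 2 to compound 4 (1.10 log units; beyond the scatter)), so the substituent on the six-membered ring decides how the exchange reads at this position. Nothing at hand accounts for these differences.

Open, from the compounds shown here alone, is whether a nitro or fluoro group on the thiophen-2-yl ring would shift the number as it does on the six-membered ring. Also open, going by these compounds, is how a pyridin-3-yl or furan-2-yl ring, or a 3-aminophenyl group, would read at this position.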